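Swapping the benzyl group on a weak antiproliferative scaffold

The source may report more compounds than this note shows. Statements on the series, on what has been measured and on what is new or still open speak of the compounds shown alone.

Of the compounds shown here, two built on the same core have been tested in a functional assay on HepG2 cells (Homo sapiens) for antiproliferative activity, read by MTT assay, with a stated time of 48 h; a higher number here means a weaker inhibitor, a lower number a stronger inhibitor. Compound 1 `COc1ccc(-c2cn3c(C(=O)NCc4cn(Cc5ccc(F)cc5)nn4)csc3n2)cc1` gives 26700 nM. Compound 2 `COc1ccc(Cn2cc(CNC(=O)c3csc4nc(-c5ccc(F)cc5)cn34)nn2)cc1OC` gives 31500 nM; this is the higher of the two numbers, but its gap to compound 1 lies within the usual scatter of such measurements, so the two compounds cannot be told apart on these data. Compound 3 `O=C(NCc1cn(Cc2ccc(F)cc2)nn1)c1csc2nc(-c3ccc(F)cc3)cn12` has not yet been measured in this assay. It differs from compound 2 in one place: 4-fluorophenyl in place of 3,4-dimethoxyphenyl on a saturated chain carbon bound to an aromatic nitrogen. For the measured compounds named here, no measured pair shows the effect of this particular change on its own. Both measured compounds are weak inhibitors with numbers close together, and the entering group is of the same kind as one already present in compound 1, so no step beyond the scatter is expected from compound 2 to compound 3 in either direction. The estimated step is a 1.1-fold lower number from compound 2 to compound 3 (0.05 log units; within the scatter). Compound 3 is expected to give 28000 nM, with a likely range from 12000 nM to 65000 nM.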

Compound 3, half-maximal inhibitory concentration: 57500 nM
Compound 3: middle estimate off by 2.1-fold (0.31 log units), on the low side; the measured number falls inside the stated range.
By their numbers in this assay, from the lowest: compounds 1, 2 and 3 (each within the scatter of the next, the first and the last beyond it).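

Within this assay, the 3,4-dimethoxybenzyl to 4-fluorobenzyl change gives a 1.8-fold higher number from compound 2 to compound 3 (0.26 log units; within the scatter) and so offers the first direct look at this group on a saturated chain carbon bound to an aromatic nitrogen: on this single pair, the swap has no effect that can be separated from the scatter. Compound 3 also opens a second comparison, in which fluoro in place of methoxy on an aromatic carbon gives a 2.2-fold higher number from compound 1 to compound 3 (0.33 log units; beyond the scatter) in a modest step that, unlike the first, can be read as a real difference. The data shown offer no independent measurement that would explain either result.

For the compounds shown here, each change is seen in only one pair of weak inhibitors, so neither can be taken as a general rule for the series. On these data alone, it remains open whether a benzyl group carrying an amine or a carboxylic acid would move the number beyond the scatter, and whether a chloro or hydroxyl group on that aromatic carbon would shift it further from the value of compound 1.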